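The compounds below may be only part of what the source reports. "The series", "measured", "known", "first", "only" and "open" are said of these compounds alone.

In a physicochemical assay for lipophilicity, at pH 7.4 (on this read-out lower numbers stand for lower lipophilicity and higher numbers for higher lipophilicity), compound 1 (`CNC(=O)c1cc(C(=O)N[C@H]2[C@@H]3COC[C@@H]32)cc2c1OC[C@@]2(CO)c1ccccc1`) reads 2.4 and compound 2 (`CNC(=O)c1cc(C(=O)N[C@H]2[C@@H]3C[C@@H](O)C[C@@H]32)cc2c1OC[C@H]2c1ccccc1`) reads 2.9 while compound 3 (`CNC(=O)c1cc(C(=O)N[C@H]2[C@@H]3COC[C@@H]32)cc2c1OC[C@H]2c1ccccn1`) reads 1.6 on the same scale. Compound 2 thus stands highest of the three, and compound 1 and compound 3 both lie lower by gaps beyond the scatter. The step from compound 2 to compound 4 (`CNC(=O)c1cc(C(=O)NC)c2c(c1)[C@H](c1ccccc1)CO2`) replaces the group on an amide-type nitrogen with methyl (one carbon atom in place of a group of 7 heavy atoms (6 carbon, 1 oxygen; one three-membered non-aromatic ring of carbon only, one five-membered non-aromatic ring of carbon only), on an amide-type nitrogen). For the measured compounds named here, no measured pair shows this change on its own, so its size remains a judgement. A moderate fall in this assay is expected, and the estimated a number 0.50 log units lower from compound 2 to compound 4 (beyond the scatter) would probably lie beyond the scatter. Compound 4 is estimated at 2.4 (expected range 2 to 2.8).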

Compound 4, distribution coefficient: 3.2
Estimate against measurement, compound 4: 0.80 log units below; the measured number lies above the stated range.
By their numbers in this assay, from the lowest: compound 3; then compound 1; then compounds 2 and 4 (each within the scatter of the next).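

In this assay, for the compounds shown here, exchanging the group of 7 heavy atoms on the amide-type nitrogen for methyl gives a number 0.30 log units higher from compound 2 to compound 4 (within the scatter), the first direct reading of a change at this position. The two rings, the hydrogen-bond donor and the hydrogen-bond acceptor of the departing group can thus all go without a step beyond the scatter on this core. Nothing available explains this result. From the compounds shown here alone, whether a longer chain or a group carrying an amine on this nitrogen would stay within the scatter of compound 4 remains open, as does whether methyl would give a similar step on the cores of compound 1 or compound 3.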